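The source may report more compounds than this note shows. Statements on the series, on what has been measured and on what is new or still open speak of the compounds shown alone.

Three compounds share one core and differ only in the group attached through the oxygen. Compound 1 `Cc1c(C2CC2)nc2ccc(-n3ccc(OCc4ccccc4)cc3=O)cn12` gives 42 nM in an assay on CHO cells for displacement of a labelled ligand from melanin-concentrating hormone receptor 1 (Homo sapiens), read by scintillation counting, with a stated time of 1 h; a higher number here means a weaker inhibitor, a lower number a stronger inhibitor. Compound 2 `Cc1c(C2CC2)nc2ccc(-n3ccc(OCc4ccc(Br)cc4)cc3=O)cn12` gives 12 nM in this assay. Compound 3 `Cc1c(C2CC2)nc2ccc(-n3ccc(OCc4ccc(C(C)C)cc4)cc3=O)cn12` gives 410 nM in this assay, the highest number of the three: a 9.8-fold higher number from compound 1 to compound 3 (0.99 log units; beyond the scatter) and a 34-fold higher number from compound 2 to compound 3 (1.53 log units; beyond the scatter).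

Compound 4 `Cc1c(C2CC2)nc2ccc(-n3ccc(OCc4ccccn4)cc3=O)cn12` is reached from compound 3 by the change (pyridin-2-yl in place of 4-isopropylphenyl on a saturated chain carbon bound to an oxygen on an aromatic ring). Going by the values given here, two measured steps bear on it. Adding isopropyl to the unsubstituted benzyl raised the number, a 9.8-fold higher number from compound 1 to compound 3 (0.99 log units; beyond the scatter), so taking the isopropyl away again should lower it by about that much. Among the compounds with values here, exchanging the remaining ring for pyridin-2-yl has no measured counterpart here, so its own effect is unknown; the number for compound 1 is the nearest anchor. A clearly lower number for compound 4 is therefore expected, a 6.8-fold lower number from compound 3 to compound 4 (0.83 log units; beyond the scatter). Compound 4 is estimated at 60 nM in this assay, with a range from 15 nM to 250 nM.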

Compound 4, half-maximal inhibitory concentration: 240 nM
The estimate for compound 4 lay 4.0-fold (0.60 log units) below the measured number; the range from low to high includes it.
By their numbers in this assay, from the lowest: compound 2; then compound 1; then compounds 4 and 3 (each within the scatter of the next).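

Changing the ring itself, rather than adding a group to it, also matters on this saturated chain carbon: in this assay, replacing phenyl with pyridin-2-yl gives a 5.7-fold higher number from compound 1 to compound 4 (0.76 log units; beyond the scatter). Replacing 4-bromophenyl with pyridin-2-yl gives a 20-fold higher number from compound 2 to compound 4 (1.30 log units; beyond the scatter), while replacing 4-isopropylphenyl with it gives a 1.7-fold lower number from compound 3 to compound 4 (0.23 log units; within the scatter), so these last two groups cannot be told apart here even though they differ in heavy-atom count. Nothing in the data shown explains why pyridin-2-yl gives this result.

The compounds shown leave open whether moving the ring nitrogen, as in pyridin-3-yl or pyridin-4-yl, would give a different number. They also leave open whether a 4-chlorophenyl or 4-methoxyphenyl group would fall nearer to the 4-bromophenyl group or to the 4-isopropylphenyl group.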